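The source may report more compounds than this note shows. Statements on the series, on what has been measured and on what is new or still open speak of the compounds shown alone.

Measured in a functional assay on A549 cells (Homo sapiens) for antiproliferative activity, read by MTT assay, with a stated time of 48 h; a higher number here means a weaker inhibitor, a lower number a stronger inhibitor:
- compound 1 `COc1ccc(N(C)c2ccnc(Cl)n2)cc1Cl`: 621 nM
- compound 2 `COc1ccc(N(C)c2ccnc(Cl)n2)cc1OCCCCBr`: 591 nM
- compound 3 `COc1ccc(N(C)c2ccnc(Cl)n2)cc1OCCC[Se]C#N`: 3710 nM

Compound 3 has the highest number of the three and is the weakest inhibitor in this assay. The measured steps to it are a 6.0-fold higher number from compound 1 to compound 3 (0.78 log units; beyond the scatter) and a 6.3-fold higher number from compound 2 to compound 3 (0.80 log units; beyond the scatter). Compound 4 `COc1ccc(N(C)c2ccnc(Cl)n2)cc1OCCCC[Se]C#N` differs from compound 3 by a group of 4 heavy atoms (2 carbon, 1 nitrogen, 1 selenium; no ring) in place of a group of 3 heavy atoms (1 carbon, 1 nitrogen, 1 selenium; no ring), on a saturated chain carbon, three bonds along the chain from an oxygen on an aromatic ring.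

For the measured compounds named here, no measured step isolates this change. The closest evidence is a 6.3-fold higher number from compound 2 to compound 3 (0.80 log units; beyond the scatter), which alters the same chain carbon and is modest in size. By contrast, a 1.1-fold lower number from compound 1 to compound 2 (0.02 log units; within the scatter) shows that the 4-bromobutoxy group in place of chloro leaves the number within the scatter. A modest shift towards a lower number is therefore expected, smaller than the step to compound 3 from compound 2, and it may not clear the scatter. The expected change is a 1.9-fold lower number from compound 3 to compound 4 (0.27 log units; within the scatter). In this assay, compound 4 is estimated at 2000 nM, with an expected range from 650 nM to 5500 nM.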

Compound 4, half-maximal inhibitory concentration: > 10000 nM
Compound 4 was reported as a limit; the forecaster's own chance of this, stated with the estimate: 3%; at least 5.0-fold (0.69 log units) between middle value and limit.
By their numbers in this assay, from the lowest: compounds 2 and 1 (each within the scatter of the next); then compound 3. At a limit, above all of these: compound 4.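

In this assay the entry for compound 4 is a limit and not a number: the limit of > 10000 nM in this assay, at which 1 of the 4 values shown sits. Even so, the step to a group of 4 heavy atoms from a group of 3 heavy atoms at this saturated chain carbon (an at least 2.6-fold higher number from compound 3 to compound 4 (0.43 log units; beyond the scatter)) lies beyond the scatter and runs upward, so the added chain carbon does not bring the lower number that the 4-bromobutoxy compound might have suggested. The earlier compounds shown here showed 4-bromobutoxy in place of chloro staying within the scatter, whereas the selenium and nitrile group in place of bromine on the same chain gives a large change (an at least 16-fold higher number from compound 2 to compound 4 (1.22 log units; beyond the scatter)), as does the comparison with the chloro compound (an at least 16-fold higher number from compound 1 to compound 4 (1.20 log units; beyond the scatter)).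

From the compounds shown here alone, two chain lengths cannot define a trend, so a longer chain carrying the same end group remains open. So does the effect of an amine or a carboxylic acid at the chain end.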